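Moving the ring double bond in a dihydrobenzodioxinyl piperazine series

A few compounds are considered here, and "the series" means these few. Any claim that something is new, unique, unknown or untested is made for them only; others in the source may bear on it.

Compound 2 `c1ccc2c(c1)CCC2CCN1CCN(c2cccc3c2OCCO3)CC1` and compound 1 `C1=C(CCN2CCN(c3cccc4c3OCCO4)CC2)c2ccccc2C1` stand level in a functional assay on the whole organism for antagonist activity, with Rattus norvegicus as the target; on this read-out higher numbers stand for an effect only at larger amounts of compound and lower numbers for an effect already at smaller amounts: compound 2 gives 0.63 mg/kg and compound 1 gives 0.63 mg/kg. Within the data shown here, the one measured step, no change at the digits printed from compound 1 to compound 2 (within the scatter), exchanges one bicyclic carbon group for another of the same size at the same place, and it leaves the dose unchanged within the scatter.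

Compound 3 `C1=C(CCN2CCN(c3cccc4c3OCCO4)CC2)Cc2ccccc21` differs from compound 2 by a group of 9 heavy atoms (9 carbon; one five-membered non-aromatic ring of carbon only, one six-membered aromatic ring of carbon only) in place of a group of 9 heavy atoms (9 carbon; one five-membered non-aromatic ring of carbon only, one six-membered aromatic ring of carbon only), on a saturated chain carbon, two bonds along the chain from an amine nitrogen in a ring, again an exchange of equal-sized carbon bicycles on the saturated chain carbon two bonds along the chain from the ring amine nitrogen. Among the measured compounds shown here, the only step that bears on it is the one from compound 1 to compound 2, and that step was flat. The expected step of no change at the digits printed from compound 2 to compound 3 (within the scatter) is therefore none beyond the scatter. Compound 3 is expected to give 0.63 mg/kg in this assay, with a range from 0.3 mg/kg to 1.3 mg/kg.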

Compound 3, minimum effective dose: 0.31 mg/kg
The estimate for compound 3 lay 2.0-fold (0.31 log units) above the measured number, and the stated range covers the measured number.
By their numbers in this assay, from the lowest: compound 3; then compounds 1 and 2 (each within the scatter of the next).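

In this assay, this position on the saturated chain carbon, which looked flat in the earlier comparison, now shows that the exact form of the bicyclic carbon group counts, with a 2.0-fold lower number from compound 2 to compound 3 (0.31 log units; beyond the scatter) and a 2.0-fold lower number from compound 1 to compound 3 (0.31 log units; beyond the scatter). Both steps are modest, and neither comes with any change in the heavy-atom count of the group. Compound 1 also carries a double bond outside the aromatic ring yet stands level with compound 2, so having such a double bond does not alone go with the lower number, and what sets compound 3 apart is where the double bond stands; no available data explain this difference.

Going by these compounds, it remains open whether this difference would persist with a longer chain in the same place. A methoxy group on the six-membered aromatic ring of the group that enters is equally untested by the compounds shown here.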